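The compounds below may be only part of what the source reports. "The series", "measured", "known", "first", "only" and "open" are said of these compounds alone.

Measured in an in vivo ADME assay on the whole organism (strain Sprague-Dawley) for pharmacokinetics, with Rattus norvegicus as the target; on this read-out higher numbers stand for fast clearance and lower numbers for slow clearance:
- compound 1 `CC(C)[C@@H]1NC[C@@H](C)Oc2ccccc2CCCNC(=O)[C@@H](Cc2ccc(F)cc2)NC(=O)[C@@H](C)N(C)C1=O`: 40 mL/min/kg
- compound 2 `CCC[C@@H]1NC[C@@H](C)Oc2ccccc2CCCNC(=O)[C@@H](Cc2ccc(F)cc2)NC(=O)[C@@H](C)N(C)C1=O`: 41 mL/min/kg
- compound 3 `C[C@@H]1CN[C@@H](C2CCCCC2)C(=O)N(C)[C@H](C)C(=O)N[C@H](Cc2ccc(F)cc2)C(=O)NCCCc2ccccc2O1`: 43 mL/min/kg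

Compound 3, at 43 mL/min/kg, lies within the scatter of both other compounds, so the series is flat so far. Compound 4 `CC[C@H](C)[C@@H]1NC[C@@H](C)Oc2ccccc2CCCNC(=O)[C@@H](Cc2ccc(F)cc2)NC(=O)[C@@H](C)N(C)C1=O` carries sec-butyl in place of cyclohexyl on a saturated ring carbon. Three measured steps change the group at this same carbon: a 1.0-fold higher number from compound 1 to compound 2 (0.01 log units; within the scatter), a 1.1-fold higher number from compound 1 to compound 3 (0.03 log units; within the scatter) and a 1.0-fold higher number from compound 2 to compound 3 (0.02 log units; within the scatter). All three stay within the scatter, so no step beyond the scatter is expected here, in either direction. The expected step is a 1.0-fold lower number from compound 3 to compound 4 (0.02 log units; within the scatter). The estimate for compound 4 is 41 mL/min/kg, with an expected range of 28 mL/min/kg to 60 mL/min/kg.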

Compound 4, clearance: 40 mL/min/kg
Compound 4: the middle estimate sits 1.0-fold (0.01 log units) above what was measured; low and high end bracket the measured number.
By their numbers in this assay, from the lowest: compounds 1, 4, 2 and 3 (each within the scatter of the next).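

In this assay, sec-butyl at this saturated ring carbon stays within the scatter of cyclohexyl (a 1.1-fold lower number from compound 3 to compound 4 (0.03 log units; within the scatter)), of propyl (a 1.0-fold lower number from compound 2 to compound 4 (0.01 log units; within the scatter)) and of isopropyl (no change at the digits printed from compound 1 to compound 4 (within the scatter)). The flat response therefore now extends to a fourth all-carbon group, one with a defined stereocentre of its own. No data shown explain this flat response.

As far as these compounds go, whether a group bearing an amine, a hydroxyl or a carboxylic acid at this carbon would give a step beyond the scatter remains open. So does the effect of the opposite configuration in the sec-butyl group.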